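A few compounds are considered here, and "the series" means these few. Any claim that something is new, unique, unknown or untested is made for them only; others in the source may bear on it.

Compound 3, with structure `COC(=O)c1cc(-c2ccccc2)c2ccc(OCc3cccc(C4(O)CCOCC4)c3)cc2c1`, gives 70 nM in an assay on isolated protein with Polyunsaturated fatty acid 5-lipoxygenase (Homo sapiens) as the target; a lower number here means a stronger inhibitor, a higher number a weaker inhibitor. Compound 1, with structure `CC(O)c1cc(-c2ccccc2)c2ccc(OCc3cccc(C4(O)CCOCC4)c3)cc2c1`, gives 520 nM in this assay. Compound 2, with structure `CC(C)(O)c1cc(-c2ccccc2)c2ccc(OCc3cccc(C4(O)CCOCC4)c3)cc2c1`, gives 1500 nM in this assay.

Compound 3 therefore holds the lowest number of the three. The two steps that reach it are a 7.4-fold lower number from compound 1 to compound 3 (0.87 log units; beyond the scatter) and a 21-fold lower number from compound 2 to compound 3 (1.33 log units; beyond the scatter), both beyond the scatter, so within this small set the methoxycarbonyl group on the shared core is tied to the strongest inhibition, while the step of a 2.9-fold higher number from compound 1 to compound 2 (0.46 log units; beyond the scatter) shows that enlarging the carbinol substituent moves the number the other way.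

Compound 4, with structure `OC1(c2cccc(COc3ccc4c(-c5ccccc5)cc(-c5nn[nH]n5)cc4c3)c2)CCOCC1`, is the next compound in line. It differs from compound 3 by 2H-tetrazol-5-yl in place of methoxycarbonyl on an aromatic carbon. Among the compounds with values here, both measured steps into compound 3 bear on this position, but they only compare methoxycarbonyl with two alcohol groups; no measured pair shows an aromatic nitrogen ring at this place, so the direction of the change has to be inferred from the fact that every departure from methoxycarbonyl seen so far has raised the number. Compound 4 is thus expected to give a somewhat higher number than compound 3, about a 4.3-fold higher number from compound 3 to compound 4 (0.63 log units; beyond the scatter), though with wide uncertainty. The estimate for compound 4 in this assay is 300 nM, within a range from 60 nM to 1500 nM.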

Compound 4, half-maximal inhibitory concentration: > 6000 nM
Compound 4: a limit, no number; the forecaster's own chance of this, stated with the estimate: 5%; middle value at least 20-fold (1.30 log units) from the limit.
By their numbers in this assay, from the lowest: compound 3; then compound 1; then compound 2. At a limit, above all of these: compound 4.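

Compound 4 stands at a limit of the assay and not at a number: the limit of > 6000 nM in this assay, at which 1 of the 4 values shown sits. In this assay, the exchange of methoxycarbonyl for 2H-tetrazol-5-yl gives an at least 85-fold higher number from compound 3 to compound 4 (1.93 log units; beyond the scatter), and the tetrazole also ranks behind both alcohol groups, with an at least 11-fold higher number from compound 1 to compound 4 (1.06 log units; beyond the scatter) and an at least 4.0-fold higher number from compound 2 to compound 4 (0.60 log units; beyond the scatter). The earlier compounds shown here showed only an order among methoxycarbonyl, 1-hydroxyethyl and 1-hydroxy-1-methylethyl; compound 4 shows that this position on the aromatic carbon can give a much weaker inhibitor than any of those three, and that the weakest inhibition seen here comes with a five-membered aromatic ring, not with the 1-hydroxy-1-methylethyl group of compound 2.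

Going by these compounds, how far compound 4 lies past its limit stays unknown, so these three steps give only a lower bound on the size of the change. The compounds shown also leave open whether a carboxylic acid, a primary amide or an oxazole at this position would stay close to compound 3 or move towards compound 4.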